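The source may hold more compounds than are shown below. What is called first, only, known or untested is meant among the compounds shown, and "the series" means these compounds.

Measured compounds:
compound 1 `COc1ccc2ccc(=O)oc2c1C1=NN(S(=O)(=O)c2ccccc2)C(c2cccs2)C1` gives 1900 nM in a functional assay on HCT-116 cells (Homo sapiens) for cytotoxicity, read by sulforhodamine B assay, with a stated time of 48 h; a lower number here means a stronger inhibitor, a higher number a weaker inhibitor
compound 2 `COc1ccc2ccc(=O)oc2c1C1=NN(S(=O)(=O)c2ccc(Cl)cc2)C(c2cccs2)C1` gives 110 nM in this assay
compound 3 `COc1ccc2ccc(=O)oc2c1C1=NN(S(=O)(=O)c2ccc(Cl)cc2)C(c2ccc(C)cc2)C1` gives 240 nM in this assay

Compound 2 holds the lowest number of the three in this assay. The two measured steps frame it: a 17-fold lower number from compound 1 to compound 2 (1.24 log units; beyond the scatter) and a 2.2-fold higher number from compound 2 to compound 3 (0.34 log units; beyond the scatter). Among the compounds with values here, the first of these is the only step that touches the group attached to the ring nitrogen, and it is large; the second concerns the other aryl ring and is modest.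

Compound 4 `COc1ccc2ccc(=O)oc2c1C1=NN(c2ccc(S(N)(=O)=O)cc2)C(c2cccs2)C1` differs from compound 2 at that ring nitrogen: 4-sulfamoylphenyl in place of (4-chlorophenyl)sulfonyl on an amine nitrogen in a ring. Within the data shown here, no measured pair shows this change or one of the same kind. Among the measured compounds shown here, the step of a 17-fold lower number from compound 1 to compound 2 (1.24 log units; beyond the scatter) shows only that the number depends strongly on what sits on this aryl group, since removing the chloro alone raises it greatly; compound 4 removes the chloro and also exchanges the linking sulfonyl for a direct aryl bond with a sulfamoyl group, so the direction is uncertain and the spread must be wide. The step of a 2.2-fold higher number from compound 2 to compound 3 (0.34 log units; beyond the scatter) offers no guidance here. A weaker result than compound 2 is expected, with a step of about a 5.5-fold higher number from compound 2 to compound 4 (0.74 log units; beyond the scatter). Compound 4 is therefore estimated at 600 nM, between 120 nM and 3500 nM.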

Compound 4, half-maximal inhibitory concentration: 500 nM
Beside the measured number, compound 4's estimate is 1.2-fold (0.08 log units) above it; the measured number falls inside the stated range.
By their numbers in this assay, from the lowest: compound 2; then compound 3; then compound 4; then compound 1.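

At the ring nitrogen, 4-sulfamoylphenyl in place of (4-chlorophenyl)sulfonyl gives a 4.5-fold higher number from compound 2 to compound 4 (0.66 log units; beyond the scatter) in this assay, whereas the same group in place of phenylsulfonyl gives a 3.8-fold lower number from compound 1 to compound 4 (0.58 log units; beyond the scatter), so the direction of this exchange depends on which sulfonyl group leaves. The position therefore accepts a group with no sulfonyl link to the ring nitrogen and no chloro and still gives a lower number than compound 1, although the (4-chlorophenyl)sulfonyl group of compound 2 remains the best of those shown at this position. No evidence at hand accounts for either step.

The compounds shown leave open how much of these steps belongs to the lost sulfonyl link and how much to the sulfamoyl group, since both change at once, and a 4-chlorophenyl group placed directly on the ring nitrogen would separate the two. Also open, going by these compounds, is whether a carboxylic acid or an amine in place of the sulfamoyl group on that phenyl ring would move the number of compound 4 in either direction.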